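Methoxy in place of chloro on the fused ring

The compounds below may be only part of what the source reports. "The series", "measured", "known", "first", "only" and "open" are said of these compounds alone.

Compound 1 `O=C(Nc1nc2ccccc2s1)c1cn(-c2ccccc2)nc1-c1ccc(F)cc1` gives 7130 nM in a functional assay on PC-3 cells (Homo sapiens) for cytotoxicity, read by MTT assay, with a stated time of 72 h; a higher number here means a weaker inhibitor, a lower number a stronger inhibitor.
Compound 2 `O=C(Nc1nc2ccc(F)cc2s1)c1cn(-c2ccccc2)nc1-c1ccc(F)cc1` gives 5260 nM in this assay.
Compound 3 `O=C(Nc1nc2ccc(Cl)cc2s1)c1cn(-c2ccccc2)nc1-c1ccc(F)cc1` gives 3170 nM in this assay.

Compound 3 carries the lowest number of the three. Its step from compound 1 is a 2.2-fold lower number from compound 1 to compound 3 (0.35 log units; beyond the scatter), while the step from compound 2 is a 1.7-fold lower number from compound 2 to compound 3 (0.22 log units; within the scatter), so compound 3 can be set apart from compound 1 but not from compound 2 on these numbers.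

Compound 4 `COc1ccc2nc(NC(=O)c3cn(-c4ccccc4)nc3-c3ccc(F)cc3)sc2c1` differs from compound 3 in one place: methoxy in place of chloro on an aromatic carbon. The measured steps that touch this position are all exchanges among hydrogen, fluoro and chloro: a 1.4-fold lower number from compound 1 to compound 2 (0.13 log units; within the scatter), a 2.2-fold lower number from compound 1 to compound 3 (0.35 log units; beyond the scatter) and a 1.7-fold lower number from compound 2 to compound 3 (0.22 log units; within the scatter). None of them involves a methoxy group, and every one of them stays small. Since the whole spread at this position across compounds 1, 2 and 3 is modest, the change to methoxy is expected to move the number only a little, most likely back toward the values of compounds 1 and 2, that is, a slightly higher number, with the step expected to be a 1.5-fold higher number from compound 3 to compound 4 (0.18 log units; within the scatter). For compound 4 the estimate in this assay is 4800 nM, with a range from 2200 nM to 10500 nM.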

Compound 4, half-maximal inhibitory concentration: 12800 nM
Beside the measured number, compound 4's estimate is 2.7-fold (0.43 log units) below it, outside the stated range (above it).
By their numbers in this assay, from the lowest: compounds 3, 2, 1 and 4 (each within the scatter of the next, the first and the last beyond it).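

In this assay the exchange of chloro for methoxy gives a 4.0-fold higher number from compound 3 to compound 4 (0.61 log units; beyond the scatter) and the exchange of fluoro for methoxy gives a 2.4-fold higher number from compound 2 to compound 4 (0.39 log units; beyond the scatter) so this position responds more strongly to the group placed on it than the exchanges among hydrogen, fluoro and chloro had shown. Measured against hydrogen, however, methoxy gives a 1.8-fold higher number from compound 1 to compound 4 (0.25 log units; within the scatter) and so compound 4 can be set apart from compound 2 and compound 3 but not from compound 1 on these numbers. No measurement at hand accounts for the result.

The compounds shown leave open whether the step follows the oxygen of the methoxy group or simply the larger group, a question that a methyl, an ethoxy or an amine at the same place could help to separate. They also leave open whether the same order would hold if another part of the shared core were changed, since all four compounds differ only at this one position.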